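A few compounds are considered here, and "the series" means these few. Any claim that something is new, unique, unknown or untested is made for them only; others in the source may bear on it.

Two compounds of the series carry a measurement in a functional assay on the whole organism with Mus musculus as the target, in the maximal electroshock model, at a dose of 50 mg/kg by the oral route (a higher number here means more inhibition at the dose given (going by the name of the read-out), a lower number less inhibition), so far. Compound 1 `CN(C)CCCCOc1ccccc1/C=C/c1ccccc1Cl` gives 14.3%. Compound 2 `CCCN(CCC)CCCCOc1ccccc1/C=C/c1ccccc1` gives 0%, the lowest of the two numbers shown, with a gap to compound 1 beyond the scatter. Compound 3 `C(=C/c1ccccc1OCCCCN1CCCCC1)\c1ccccc1` is not yet measured and differs from compound 2 in one place: piperidin-1-yl in place of dipropylamino on a saturated chain carbon, four bonds along the chain from an oxygen on an aromatic ring. Among the compounds with values here, no step between measured compounds is at hand to size this change. The step from compound 2 to compound 3 expected in this assay, a number 8 percentage points higher from compound 2 to compound 3 (within the scatter), is small and upward if anything, possibly none beyond the scatter. Compound 3 is therefore estimated at 8%, within a range from 0% to 25%.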

Compound 3, a percentage reported as inhibition, in the whole organism at one dose (the size of the read-out at that dose, not a potency): 42.9%
For compound 3 the middle estimate is 34.9 percentage points below the measured one; the measured number lies above the stated range.
By their numbers in this assay, from the lowest: compound 2; then compound 1; then compound 3.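

In this assay, the group on a saturated chain carbon, four bonds along the chain from an oxygen on an aromatic ring, clearly matters: piperidin-1-yl in place of dipropylamino gives a number 42.9 percentage points higher from compound 2 to compound 3 (beyond the scatter). Within the data shown here, this is the first sized step at this position, and it is large for a change from an open-chain amine to a six-membered ring amine.

On these data alone, whether morpholin-4-yl or pyrrolidin-1-yl at the same place would match piperidin-1-yl remains open. No measurement at hand gives a reason for the size of this step.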